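Dropping the sulfamoyl group from a diarylamine compound

The source may report more compounds than this note shows. Statements on the series, on what has been measured and on what is new or still open speak of the compounds shown alone.

Measured compounds:
Compound 1, `N=C(N)c1ccc(Nc2ncnc(Nc3ccc(S(N)(=O)=O)cc3)c2[N+](=O)[O-])cc1`, gives 28%.
Compound 2, `COc1cc(Nc2ncnc(Nc3ccc(C(=N)N)cc3)c2[N+](=O)[O-])cc(OC)c1OC`, gives 44%.

Both compounds share a nitrated pyrimidine core bearing two anilines, one of them carrying an amidine. In an assay on isolated protein for inhibition of protein arginine N-methyltransferase 1 (Homo sapiens), read by AlphaLISA, with a stated time of 60 min, tested at 50 uM (a higher number here means more inhibition at the concentration tested (going by the name of the read-out), a lower number less inhibition), compound 1 gives 28%, the lower of the two numbers recorded, while in this assay compound 2 gives 44%, a reading beyond the usual scatter above it. Compound 3, `N=C(N)c1ccc(Nc2ncnc(Nc3ccccc3)c2[N+](=O)[O-])cc1`, has not yet been measured. It differs from compound 1 in one place: hydrogen in place of sulfamoyl on an aromatic carbon. Within the data shown here, no measured pair shows this change on its own, so its effect is not known from the data. The expected step of a number 3 percentage points lower from compound 1 to compound 3 (within the scatter) is small and judged not to lie beyond the scatter. Compound 3 is therefore estimated at 25%, within a range of 5% to 45%.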

Compound 3, a percentage reported as inhibition, at one concentration (the size of the read-out at that concentration, not a potency): 9%
Compound 3: middle estimate off by 16 percentage points, on the high side; measured number inside the range.
By their numbers in this assay, from the lowest: compound 3; then compound 1; then compound 2.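

In this assay, among these compounds, putting hydrogen in place of sulfamoyl on this aromatic carbon gives a number 19 percentage points lower from compound 1 to compound 3 (beyond the scatter), the first reading of this change on its own. It shows that this place on the ring is not indifferent: the 4-sulfamoylphenyl of compound 1 retains more inhibition at the concentration tested than the phenyl of compound 3. Nothing in the data accounts for this step.

Still open, going by these compounds, is whether sulfamoyl is particular in this respect, or whether another group on the same carbon, such as an amine, a carboxylic acid or a methyl sulfone, would read the same. Also open, on these data alone, is how a single methoxy group there would compare, a group that appears in compound 2 only alongside others on its ring.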